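The source may hold more compounds than are shown below. What is called first, only, known or untested is meant among the compounds shown, and "the series" means these compounds.

Measured compounds in a functional assay on PC-3 cells (Homo sapiens) for antiproliferative activity; on this read-out higher numbers stand for weaker inhibition of growth and lower numbers for stronger inhibition of growth:

Compound 1 `Cc1cnc2[nH]c(-c3cccc(F)c3)cc(=O)c2c1` gives 34.7 nM.
Compound 2 `Cc1cc(C)c2c(O)cc(-c3ccc4ccccc4c3)nc2n1` gives 5500 nM.

Of these two numbers, compound 2 carries the higher one, and by a wide margin: its nearest neighbour in this assay is compound 1, whose number is lower by a gap that lies well beyond the usual scatter of repeated measurements. Compound 2 is thus the weaker inhibitor of growth among the two measured compounds.

Among the measured compounds shown here, no pair of measured compounds differs in only one place, so no measured step can be carried over to the next compound. Compound 3 `Cc1ccnc2nc(-c3ccc4ccccc4c3)cc(O)c12` is as yet unmeasured in this assay and differs from compound 2 in a single respect: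

hydrogen in place of methyl on an aromatic carbon

The change is small in size and removes a single carbon without altering the count of hydrogen-bond donors or acceptors, and nothing in the two measured compounds speaks to what such a removal does. The step from compound 2 to compound 3 is therefore expected to be none beyond the scatter, with the estimate no change at the digits printed from compound 2 to compound 3 (within the scatter). Compound 3 is expected to give about 5500 nM in this assay, within the range 1800 nM to 17000 nM.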

Compound 3, concentration for 50% growth inhibition: 1380 nM
Estimate against measurement, compound 3: 4.0-fold (0.60 log units) above; measured number below the stated range.
By their numbers in this assay, from the lowest: compound 1; then compound 3; then compound 2.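

In this assay, among the compounds shown here, the change gives the first measured single-place step: a 4.0-fold lower number from compound 2 to compound 3 (0.60 log units; beyond the scatter) on replacing methyl with hydrogen. This shows that the aromatic carbon next to the ring nitrogen is not indifferent to what it carries, since the step is modest but lies beyond the scatter, and here hydrogen goes with stronger inhibition of growth than methyl. Nothing measured on these compounds bears on the reason for this step, so only its direction and size can be stated.

Going by these compounds, it remains open whether any group larger than hydrogen at this carbon would give a weaker number, as methyl does, or whether the outcome depends on the group, as an ethyl chain, a methoxy group, a chlorine atom or an amine might show. Also open, on these data alone, is whether the same replacement would give a step of similar size on the core of compound 1, and what replacing the methyl group that remains in compound 3 would do.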